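The source may hold more compounds than are shown below. What is called first, only, known or untested is meant among the compounds shown, and "the series" means these compounds.

Measured so far: compound 1 `CC(=O)N1CCC(n2cc(-c3cnc(N)c4oc(-c5cnc6cnccn56)cc34)cn2)CC1` with 0.52; compound 2 `CC(=O)N1CCC(n2cc(-c3cnc(N)c4oc(-c5cccc6ccccc56)cc34)cn2)CC1` with 0.77.

In an ADME assay on microsomes from liver (Mus musculus) for metabolic stability (a higher number here means that the liver removes a larger share of the compound in one pass, a lower number that the liver removes a smaller share), compound 2 stands highest of the two numbers, giving 0.77, while compound 1 gives 0.52. Compound 3 `CC(=O)N1CCC(n2cc(-c3cnc(N)c4oc(-c5cccc6nnsc56)cc34)cn2)CC1` differs from compound 2 by a group of 9 heavy atoms (6 carbon, 2 nitrogen, 1 sulfur; one five-membered aromatic ring with 3 hetero atoms, one six-membered aromatic ring of carbon only) in place of a group of 10 heavy atoms (10 carbon; 2 six-membered aromatic rings of carbon only), on an aromatic carbon. Going by the values given here, the one measured step bearing on this is a number 0.25 higher from compound 1 to compound 2 (beyond the scatter), in which a carbon-only bicycle took the place of a nitrogen-containing bicycle. Compound 3 goes the other way, bringing back a heteroaromatic bicycle, though one keeping a carbon-only six-membered ring. For compound 3 a drop is expected, smaller than that earlier step: a number 0.15 lower from compound 2 to compound 3 (beyond the scatter). Compound 3 is estimated at 0.62, range 0.48 to 0.76.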

Compound 3, hepatic extraction ratio: 0.7
Compound 3: middle estimate off by 0.080, on the low side, within the range that was stated.
By their numbers in this assay, from the lowest: compound 1; then compounds 3 and 2 (each within the scatter of the next).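

In this assay, putting the sulfur-containing bicycle in place of naphthalen-1-yl, next to the ring oxygen, gives a number 0.070 lower from compound 2 to compound 3 (within the scatter), so these two groups are not told apart despite the hydrogen-bond acceptors of the entering group. The comparison with the other heteroaromatic bicycle gives a number 0.18 higher from compound 1 to compound 3 (beyond the scatter), so hetero atoms in this group do not by themselves go with the lower number of compound 1. No available measurement accounts for these differences. Left open is how a single phenyl ring or an aliphatic amine at this place would read in this assay.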